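Benzamido for phenylsulfonyl on the ester arm

The compounds below may be only part of what the source reports. "The series", "measured", "known", "first", "only" and "open" are said of these compounds alone.

Three compounds of the series have numbers in an assay on isolated protein for binding affinity to Type-2 angiotensin II receptor (Homo sapiens); on this read-out higher numbers stand for weaker inhibition and lower numbers for stronger inhibition. Compound 1 `CCCc1nc(CC)c(C(=O)OCc2ccccc2S(=O)(=O)c2ccccc2)n1Cc1ccc(-c2ccccc2S(=O)(=O)NC(=O)OCCC(C)C)cc1F` gives 5 nM in this assay. Compound 2 `CCCc1nc(CC)c(C(=O)OCc2ccc(C(=O)c3ccccc3)cc2)n1Cc1ccc(-c2ccccc2-c2nn[nH]n2)cc1` gives 2000 nM and compound 3 `CCCCN(Cc1ccccc1)C(=O)CCCOC(=O)c1c(CC)nc(CCC)n1Cc1ccc(-c2ccccc2-c2nn[nH]n2)cc1` gives 300 nM. Compound 1 thus stands lowest of the three: compound 3 lies nearest with a higher number and compound 2 furthest, both gaps beyond the scatter. Within the data shown here, compound 2 and compound 3 differ from compound 1 in several places, so no single step is isolated among them.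

Compound 4 `CCCc1nc(CC)c(C(=O)OCc2ccccc2NC(=O)c2ccccc2)n1Cc1ccc(-c2ccccc2S(=O)(=O)NC(=O)OCCC(C)C)cc1F` is not yet measured. It differs from compound 1 in one place: benzamido in place of phenylsulfonyl on an aromatic carbon. The change sits on the ester arm, away from the acidic sulfonylcarbamate. A small step, from compound 1 to compound 4, toward a somewhat higher number is expected, a 2.0-fold higher number from compound 1 to compound 4 (0.30 log units; within the scatter), not clearly beyond the scatter. Compound 4 is estimated at 10 nM, with a range from 3 nM to 40 nM.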

Compound 4, half-maximal inhibitory concentration: 1 nM
The estimate for compound 4 lay 10-fold (1.00 log units) above the measured number; the whole stated range lies above it.
By their numbers in this assay, from the lowest: compound 4; then compound 1; then compound 3; then compound 2.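

In this assay, among these compounds, benzamido in place of phenylsulfonyl on an aromatic carbon, ortho to a large group, gives a 5.0-fold lower number from compound 1 to compound 4 (0.70 log units; beyond the scatter), the first single-place step. This place on the ester arm therefore responds to the exchange of one group for another with the same heavy-atom count. Nothing shown accounts for the step.

Open, as far as these compounds go, is whether N-methylbenzamido or an acetamido group at this place would keep the number of compound 4. Also open, from the compounds shown here alone, is how benzamido behaves elsewhere on that ring.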